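The source may hold more compounds than are shown below. What is called first, only, known or untested is meant among the compounds shown, and "the series" means these compounds.

Compound 1 `CSc1nc(Cl)c(C(=O)c2ccccc2)s1`: > 100000 nM
Compound 2 `CSc1nc(Br)c(C(=O)c2ccccc2)s1`: > 100000 nM
Compound 3 `N#Cc1sc(N2CCCC2)nc1Cl`: > 100000 nM

All three compounds were tested in a functional assay on PC-3 cells (Homo sapiens) for cytotoxicity, read by MTT assay, with a stated time of 72 h (a lower number here means a stronger inhibitor, a higher number a weaker inhibitor), and each entry is a limit of the assay, not a number. The whole set therefore comes down to one observation: the limit of > 100000 nM in this assay, at which 3 of the 3 values shown sit. Compound 1 has only its limit of > 100000 nM to stand on.

Compound 4 `O=C(c1ccccc1)c1sc(N2CCCCC2)nc1Cl` keeps the chloro group and the rest of compound 1, and differs in one place: piperidin-1-yl in place of methylsulfanyl on an aromatic carbon. For the measured compounds named here, the only measured step, a step that the two limits leave unreadable from compound 1 to compound 2, swaps the chloro group rather than the methylsulfanyl group, and it has no readable size. Going by the values given here, no measured step therefore shows what this change does. With compound 1, compound 2 and compound 3 all at the limit, the expectation in this assay is for no clear gain in potency, although a small one cannot be ruled out. The expected change is a number no higher from compound 1 to compound 4 (the limit leaves the size open). Compound 4 is estimated at 100000 nM, with an expected range of 30000 nM to 300000 nM.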

Compound 4, half-maximal inhibitory concentration: 69000 nM
For compound 4 the middle estimate is 1.4-fold (0.16 log units) above the measured one; measured number inside the range.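

Compound 4 is the only compound shown that gives a number rather than a limit in this assay, so a group on this ring carbon, next to the ring nitrogen and next to the ring sulfur, can go with a readable value. Piperidin-1-yl in place of methylsulfanyl gives an at least 1.4-fold lower number from compound 1 to compound 4 (0.16 log units; that floor lies within the scatter), so this change cannot yet be called a real gain in potency, although the true size of the step may be larger. Every other value shown remains a limit, so the new number has little to be set against: the limit of > 100000 nM in this assay, at which 3 of the 4 values shown sit.

The compounds shown leave open whether another amine at this position, such as a morpholine ring or a simple primary amine, would give a lower number. They also leave open whether piperidin-1-yl would give a readable value with bromo in place of chloro.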